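Swapping a Pyrazole for a Difluorocyclohexene: Solubility Outlook

The compounds below may be only part of what the source reports. "The series", "measured", "known", "first", "only" and "open" are said of these compounds alone.

Measured compounds:
compound 1, `Cc1cc(NCc2ccccn2)n2ncc(-c3ccc(F)cc3)c2n1`, < 5000 nM
compound 2, `Cc1cc(NCc2ccccn2)n2ncc(-c3ccn(C)n3)c2n1`, 188000 nM

The shared core carries a pyridinylmethylamino group and a variable ring on the bicyclic aromatic system. In a physicochemical assay for solubility, read by HPLC, using the shake flask method, measured as kinetic solubility, with a stated time of 2 h, at pH 7.4 (a higher number here means a more soluble compound, a lower number a less soluble compound), compound 2 gives 188000 nM, and this is the only number shown. For compound 1 the result is a limit of the assay, < 5000 nM; the limit of < 5000 nM in this assay, at which 1 of the 2 values shown sits, is where that value sits. Among the compounds with values here, the one measured step, an at least 37-fold higher number from compound 1 to compound 2 (1.57 log units; beyond the scatter), is the sole guide, and it is large.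

Compound 3, `Cc1cc(NCc2ccccn2)n2ncc(C3=CCC(F)(F)CC3)c2n1`, differs from compound 2 by 4,4-difluorocyclohex-1-en-1-yl in place of 1-methyl-1H-pyrazol-3-yl on an aromatic carbon. This change runs opposite in character to the measured step, taking the ring from a heterocycle back to a carbocycle, although a non-aromatic, fluorinated one rather than the fluorophenyl of compound 1. Given the size of the step from compound 1 to compound 2, a drop in solubility is expected for compound 3, estimated as a 9.4-fold lower number from compound 2 to compound 3 (0.97 log units; beyond the scatter). Compound 3 is expected to give about 20000 nM in this assay, within a range of 4000 nM to 100000 nM, with a fair chance that only a limit is reported.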

Compound 3, solubility: 5000 nM
Compound 3: middle estimate off by 4.0-fold (0.60 log units), on the high side, and the stated range covers the measured number.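

In this assay, within the data shown here, the change from 1-methyl-1H-pyrazol-3-yl to 4,4-difluorocyclohex-1-en-1-yl gives a 38-fold lower number from compound 2 to compound 3 (1.58 log units; beyond the scatter), the first step at this aromatic carbon with a number at both ends and therefore a size that can be read in full. It also shows that a non-aromatic ring of carbon only, and not just the aromatic 4-fluorophenyl group, can stand far from the pyrazole in this assay. Compound 1 gives < 5000 nM, which is a limit of the assay, and the other new step, a number no lower from compound 1 to compound 3 (the limit leaves the size open), cannot be read in size because it stays open at that limit: the limit of < 5000 nM in this assay, at which 1 of the 3 values shown sits.

The compounds shown leave open which feature of the entering group goes with the lower number, since the fluorine atoms, the double bond outside aromatic rings and the loss of the ring nitrogens all change together in this one step. They also leave open how a saturated ring carrying an amine, such as a piperidine or a morpholine, would read at this position.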